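A few compounds are considered here, and "the series" means these few. Any claim that something is new, unique, unknown or untested is made for them only; others in the source may bear on it.

Of the compounds shown here, three sharing one core have been tested in an in vitro functional assay on HEK285-7 cells for antagonist activity at prostaglandin D2 receptor 2 (Homo sapiens), read by BRET and beta-arrestin recruitment; a higher number here means a weaker inhibitor, a lower number a stronger inhibitor. Compound 1 `COc1ccc(OC)c(-c2nc(C(c3ccccc3)c3ccccc3)sc2CC(=O)O)c1` gives > 100000 nM, which is the limit of > 100000 nM in this assay, at which 1 of the 3 values shown sits, a limit rather than a measured number. Compound 2 `O=C(O)Cc1sc(C(c2ccccc2)c2ccc(O)cc2)nc1-c1ccc(F)cc1` gives 30 nM in this assay. Compound 3 `N#Cc1ccc(-c2nc(C(c3ccc(F)cc3)c3ccc(F)cc3)sc2CC(=O)O)cc1` gives 1500 nM in this assay, the higher of the two numbers available, with compound 2 sitting far lower, a gap well beyond the usual scatter of the assay. Compound 4 `O=C(O)Cc1sc(C(c2ccc(F)cc2)c2ccc(F)cc2)nc1-c1cc(F)nc(F)c1` has not yet been measured. It differs from compound 3 in a single place: 2,6-difluoropyridin-4-yl in place of 4-cyanophenyl on an aromatic carbon. One six-membered aromatic ring is thus exchanged for another of the same size. Among the compounds with values here, no pair of measured compounds differs in just this way, so the size of the step cannot be read from the data. The step is expected to be small, within or only just beyond the scatter, leaning toward a lower number: a 1.7-fold lower number from compound 3 to compound 4 (0.22 log units; within the scatter). The estimate for compound 4 in this assay is 900 nM, within a range from 200 nM to 5000 nM.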

Compound 4, half-maximal inhibitory concentration: 110 nM
Compound 4: the middle estimate sits 8.2-fold (0.91 log units) above what was measured, outside the stated range (below it).
By their numbers in this assay, from the lowest: compound 2; then compound 4; then compound 3. At a limit, above all of these: compound 1.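

The exchange of 4-cyanophenyl for 2,6-difluoropyridin-4-yl gives a 14-fold lower number from compound 3 to compound 4 (1.13 log units; beyond the scatter) in this assay, so this position, on the aromatic carbon next to the ring nitrogen, responds strongly to the choice of six-membered ring. The two groups match in heavy atoms, hydrogen-bond donors and acceptors and net charge, so those counts alone do not set the number here. Nothing measured here accounts for the size of this step.

The change swaps the nitrile for two fluorines and puts a nitrogen into the ring all at once, and the compounds shown cannot say which of these carries the step. A plain pyridine ring or a difluorophenyl ring at this position, each with the rest of compound 4 unchanged, would separate those parts.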